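The compounds below may be only part of what the source reports. "The series", "measured", "known", "first", "only" and "open" are said of these compounds alone.

Measured so far in a functional assay on the whole organism for agonist activity, with Mus musculus as the target; on this read-out lower numbers stand for an effect already at smaller amounts and higher numbers for an effect only at larger amounts of compound (every value a limit of the assay, not a number):
- compound 1 (`O=C1CCCN1CC#CCn1cnc2ccccc21`) reads > 100 mg/kg
- compound 2 (`CC(=O)NCC#CCn1ccnc1`) reads > 100 mg/kg
- compound 3 (`CC(=O)NCC#CCn1cncc1C`) reads > 100 mg/kg

Compound 3 stands at > 100 mg/kg as a limit and not as a number. The series offers no numerical reading yet, with the limit of > 100 mg/kg in this assay, at which 3 of the 3 values shown sit, being all that can be said so far.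

Compound 4 (`COC(=O)NCC#CCn1cncc1C`) changes one place of compound 3, with methoxy in place of methyl on a carbonyl carbon, acetamido to (methoxycarbonyl)amino (methoxy in place of methyl on a carbonyl carbon).

For the measured compounds named here, the only measured step between close neighbours is a step that the two limits leave unreadable from compound 2 to compound 3 and it concerns methyl in place of hydrogen on an aromatic carbon, not the carbonyl carbon. Going by the values given here, no measured step therefore bears directly on this change, and none has a readable size that could be carried over to this assay as a guide.

With compound 3 at > 100 mg/kg as the only starting point, no direction can be argued, and the expected outcome is a step that the limit leaves unreadable from compound 3 to compound 4 with wide uncertainty. For compound 4 the estimate is 120 mg/kg with 40 mg/kg to 300 mg/kg as the expected range, and a further limit reading is the likeliest result.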

Compound 4, dose for half-maximal effect: > 100 mg/kg
Compound 4: only a limit was reported; the forecaster's own chance of this, stated with the estimate: 70%; the middle value does not contradict the limit.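

No new step can be read: compound 3 and compound 4 both stand only as limits in this assay, which leaves methoxy in place of methyl on the carbonyl carbon without a readable size. The compounds shown leave open whether any member of the series reaches a numerical value, since all share one limit: the limit of > 100 mg/kg in this assay, at which 4 of the 4 values shown sit.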